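The compounds below may be only part of what the source reports. "The series", "measured", "known", "first", "only" and "open" are said of these compounds alone.

Measured compounds:
- compound 1, `COc1ccc(-c2nc(SC)n(C)c(=O)c2C#N)cc1`, 48 ug/mL in a functional assay, with a stated time of 10 min; a higher number here means a weaker inhibitor, a lower number a stronger inhibitor
- compound 2, `CCOC(=O)c1cnn(-c2nc(-c3ccc(OC)cc3)c(C#N)c(=O)n2C)c1N`, 74 ug/mL in this assay
- compound 3, `CSc1nc(-c2ccccc2O)c(C#N)c(=O)n1C`, 39 ug/mL in this assay

Compound 2 gives the highest of the three numbers, yet its gaps to compound 1 and to compound 3 both sit within the usual scatter, so the three compounds cannot be separated on these data. Compound 4, `CCOC(=O)c1cnn(-c2nc(-c3ccccc3Cl)c(C#N)c(=O)n2C)c1N`, is not yet measured. It differs from compound 2 in one place: 2-chlorophenyl in place of 4-methoxyphenyl on an aromatic carbon. For the measured compounds named here, no measured pair shows this exchange, and no pair here differs in only one place, so there is no step to lean on. The expectation for compound 4 is therefore a number near that of compound 2, with a 1.1-fold lower number from compound 2 to compound 4 (0.06 log units; within the scatter) not beyond the scatter. Compound 4 is estimated at 65 ug/mL, between 30 ug/mL and 140 ug/mL.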

Compound 4, half-maximal inhibitory concentration: 98 ug/mL
Compound 4: the middle estimate sits 1.5-fold (0.18 log units) below what was measured, within the range that was stated.
By their numbers in this assay, from the lowest: compounds 3, 1, 2 and 4 (each within the scatter of the next, the first and the last beyond it).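

In this assay, for the compounds shown here, putting 2-chlorophenyl in place of 4-methoxyphenyl on this aromatic carbon, ortho to a cyano group, gives a 1.3-fold higher number from compound 2 to compound 4 (0.12 log units; within the scatter) and is the first one-place exchange seen at this position. The two aryl groups cannot be told apart here, so neither the change of substituent nor its place on the phenyl ring shows a measurable effect. No separate measurement bears on this result.

As far as these compounds go, it remains open whether an amine, a carboxylic acid or a longer alkyl chain at this position would move the number beyond the scatter.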